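Dropping the methyl from the anilide of compound 1

The source may hold more compounds than are shown below. What is called first, only, known or untested is meant among the compounds shown, and "the series" means these compounds.

Compound 1 `Cc1ccc(NC(=O)CCc2cn(Cc3ccc4oc(-c5ccccc5)cc(=O)c4c3)nn2)cc1` gives 15600 nM in an assay on isolated protein for inhibition of Amine oxidase [flavin-containing] B (Homo sapiens), read by fluorescence and spectrophotometry; a higher number here means a weaker inhibitor, a lower number a stronger inhibitor. Compound 2 `O=C(NCc1cnnn1Cc1ccc2oc(-c3ccc(Cl)cc3)cc(=O)c2c1)c1ccccc1` gives 32900 nM in this assay. Compound 3 `O=C(CCc1cn(Cc2ccc3oc(-c4ccc(Cl)cc4)cc(=O)c3c2)nn1)Nc1ccc(Cl)cc1` gives 32900 nM in this assay.

Compound 1 holds the lowest number of the three, and its gaps to compound 2 and to compound 3 both lie beyond the scatter, so it is the strongest inhibitor measured here. Compound 4 `O=C(CCc1cn(Cc2ccc3oc(-c4ccccc4)cc(=O)c3c2)nn1)Nc1ccccc1` differs from it by one change: hydrogen in place of methyl on an aromatic carbon. Among the measured compounds shown here, no measured pair shows what this change does. A single methyl removed from the amide-bearing ring is expected to move the number little, if at all, in this assay, so the step of a 1.3-fold higher number from compound 1 to compound 4 (0.11 log units; within the scatter) is estimated to stay within the scatter. Compound 4 is accordingly expected to give about 20000 nM, within a range of 8000 nM to 50000 nM.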

Compound 4, half-maximal inhibitory concentration: 15600 nM
For compound 4 the middle estimate is 1.3-fold (0.11 log units) above the measured one; low and high end bracket the measured number.
By their numbers in this assay, from the lowest: compounds 1 and 4 (each within the scatter of the next); then compounds 2 and 3 (each within the scatter of the next).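

In this assay, among the compounds shown here, the swap of methyl for hydrogen, on the aromatic ring para to a large group, gives no change at the digits printed from compound 1 to compound 4 (within the scatter) and is the first single change read directly. The 4-methylphenyl and phenyl amides therefore stand level, and the methyl is not needed to hold the number of compound 1 in this assay. Nothing at hand explains this result.

From the compounds shown here alone, whether a methoxy, an amine or a carboxylic acid at this position would move the number remains open.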